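The compounds below may be only part of what the source reports. "The series", "measured", "known", "first", "only" and "open" are said of these compounds alone.

From the compounds shown here alone, the study concerns three sulfonamides tested in an assay on isolated protein for inhibition of malate dehydrogenase, mitochondrial (Sus scrofa), with stated times of 45 min and 30 min (on this read-out lower numbers stand for stronger inhibition and higher numbers for weaker inhibition), and a fourth that remains untested. Compound 1 `O=S(=O)(Nc1ccc(-c2nc3ccccc3o2)cc1)c1ccc(F)c(C(F)(F)F)c1` carries a fluorinated, trifluoromethyl-bearing aryl on the sulfonyl sulfur. In this assay compound 1 gives > 63000 nM, which is a limit of the assay and not a number. Compound 3 `O=S(=O)(Nc1ccc(-c2nc3ccccc3o2)cc1)c1ccccc1O` places a 2-hydroxyphenyl on the sulfonyl sulfur. In this assay compound 3 gives > 63000 nM, again only a limit. Compound 2 `O=S(=O)(Nc1ccc2oc(-c3ccccc3)nc2c1)c1ccccc1O` also carries a 2-hydroxyphenyl on the sulfonyl sulfur. In this assay compound 2 gives > 63000 nM, likewise a limit. Compound 2 therefore stands where every shown value stands, at the limit of > 63000 nM in this assay, at which 3 of the 3 values shown sit, and no compound can be ranked against another. Compound 4 `COc1cccc(S(=O)(=O)Nc2ccc3oc(-c4ccccc4)nc3c2)c1` differs from compound 2 in one place (3-methoxyphenyl in place of 2-hydroxyphenyl on a sulfonyl sulfur). For the measured compounds named here, all measured values are limits, and no step between measured compounds exists to gauge this change. Compound 4 is expected to remain at the same limit, with an expected step that the limit leaves unreadable from compound 2 to compound 4 of no size beyond the scatter. The estimate for compound 4 in this assay is 100000 nM, within a range from 30000 nM to 400000 nM.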

Compound 4, half-maximal inhibitory concentration: > 63000 nM
Compound 4 ended at the assay's limit; the forecaster's own chance of this, stated with the estimate: 85%; the middle value does not contradict the limit.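

No step can be read from compound 2 to compound 4, since both values in this assay are limits of the assay and not numbers: the limit of > 63000 nM in this assay, at which 4 of the 4 values shown sit.

The compounds shown leave open whether 3-methoxyphenyl and 2-hydroxyphenyl on the sulfonyl sulfur differ at all, and what level of inhibition either group gives.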